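Fluoro for hydrogen on the fused ring of compound 3

The source may report more compounds than this note shows. Statements on the series, on what has been measured and on what is new or still open speak of the compounds shown alone.

Measured compounds:
Compound 1, `CCn1c(=O)/c(=C2\Sc3cc(F)ccc3N2C)s/c1=C\c1ccncc1Nc1ccccc1F`: 150 nM
Compound 2, `CCn1c(=O)/c(=C2\Sc3ccccc3N2C)s/c1=C\c1ccncc1Nc1cc(C)ccc1C`: 1800 nM
Compound 3, `CCn1c(=O)/c(=C2\Sc3ccccc3N2C)s/c1=C\c1ccncc1Nc1ccccc1C`: 470 nM

In a functional assay on CWR22R cells (Homo sapiens) for inhibition (a lower number here means a stronger inhibitor, a higher number a weaker inhibitor), compound 3 gives 470 nM, the second highest of the three numbers. Compound 1 gives 150 nM, and compound 2 gives 1800 nM. Going by the values given here, the only step between compounds that differ in one place is a 3.8-fold lower number from compound 2 to compound 3 (0.58 log units; beyond the scatter), and it concerns the group on the aniline ring rather than the fused ring.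

Compound 4, `CCn1c(=O)/c(=C2\Sc3cc(F)ccc3N2C)s/c1=C\c1ccncc1Nc1ccccc1C`, differs from compound 3 as follows: fluoro in place of hydrogen on an aromatic carbon. Among the compounds with values here, no measured pair shows this change by itself: compound 1 carries the fluoro on the fused ring but also differs from compound 3 at the aniline ring, so its lower number cannot be read as the effect of the fluoro alone. The step for compound 4 in this assay is therefore estimated as a 1.6-fold lower number from compound 3 to compound 4 (0.19 log units; within the scatter), a small gain that may not reach beyond the scatter. Compound 4 is expected to give 300 nM, within 120 nM to 750 nM.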

Compound 4, half-maximal inhibitory concentration: 2300 nM
For compound 4 the middle estimate is 7.7-fold (0.88 log units) below the measured one; the measured number lies above the stated range.
By their numbers in this assay, from the lowest: compound 1; then compound 3; then compounds 2 and 4 (each within the scatter of the next).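

In this assay the fluoro on the fused ring brings no gain when the aniline ring carries methyl: the change gives a 4.9-fold higher number from compound 3 to compound 4 (0.69 log units; beyond the scatter) and so costs activity at this position. With that fluoro held in place, the group on the aniline ring matters a great deal, as methyl in place of fluoro there gives a 15-fold higher number from compound 1 to compound 4 (1.19 log units; beyond the scatter) and shows that the fused-ring fluoro alone does not account for the low number of compound 1. Nothing available here explains either step.

On these data alone, it remains open whether the fused-ring fluoro would also raise the number in a compound with fluoro on the aniline ring, where hydrogen and fluoro on the fused ring could be compared directly. As far as these compounds go, it is equally open whether chloro or methoxy at the same place on the fused ring would behave as fluoro does.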